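Acylthiourea variation in the chlorophenoxy-linked indoline series

A few compounds are considered here, and "the series" means these few. Any claim that something is new, unique, unknown or untested is made for them only; others in the source may bear on it.

Measured so far in an ADME assay on Huh-7 cells (Homo sapiens) for cytotoxicity; on this read-out lower numbers stand for higher toxicity in this test and higher numbers for lower toxicity in this test:
- Compound 1 `NC(=S)N1CCc2c(OCCCCCOc3ccc(Cl)cc3)cccc21`: a limit of the assay, > 50000 nM.
- Compound 2 `O=C(NC(=S)N1CCc2c(OCCCCCOc3ccc(Cl)cc3)cccc21)Oc1ccccc1`: likewise only a limit, > 50000 nM.
- Compound 3 `COc1ccc(C(=O)NC(=S)N2CCc3c(OCCCCCOc4ccc(Cl)cc4)cccc32)cc1`: 34400 nM.

Compound 2 thus stands at the upper limit of this assay, where no number is read; it shares this position with compound 1, as recorded in the limit of > 50000 nM in this assay, at which 2 of the 3 values shown sit. Within the data shown here, compound 3 is the only member with a number, and the step of an at least 1.4-fold lower number from compound 2 to compound 3 (0.16 log units; that floor lies within the scatter) is readable only as a floor, which lies within the scatter.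

Compound 4 `O=C(NC(=S)N1CCc2c(OCCCCCOc3ccc(Cl)cc3)cccc21)c1ccco1` differs from compound 2 by furan-2-yl in place of phenoxy on a carbonyl carbon. Among the measured compounds shown here, the one measured step that bears on it is the exchange of phenoxy for an aryl group on the same carbonyl carbon, an at least 1.4-fold lower number from compound 2 to compound 3 (0.16 log units; that floor lies within the scatter); the step that the two limits leave unreadable from compound 1 to compound 2 is unreadable. A move from phenoxy to a small aromatic ring has so far given at most a modest drop, so for compound 4 a step no larger than the scatter is expected, an at least 1.1-fold lower number from compound 2 to compound 4 (0.04 log units; that floor lies within the scatter), with a fair chance that only a limit is reported again.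

Estimated for compound 4: 45000 nM, range 22000 nM to 90000 nM.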

Compound 4, half-maximal cytotoxic concentration: 4620 nM
For compound 4 the middle estimate is 9.7-fold (0.99 log units) above the measured one; measured number below the stated range.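

In this assay the group on the carbonyl carbon now makes a difference beyond the scatter: furan-2-yl in place of phenoxy gives an at least 10-fold lower number from compound 2 to compound 4 (1.03 log units; beyond the scatter), and furan-2-yl in place of 4-methoxyphenyl gives a 7.4-fold lower number from compound 3 to compound 4 (0.87 log units; beyond the scatter). Set against the parent thiourea, (furan-2-yl)carbonyl in place of hydrogen on the amide-type nitrogen gives an at least 10-fold lower number from compound 1 to compound 4 (1.03 log units; beyond the scatter), so a carbonyl at this nitrogen does not by itself set the read-out. The steps from compound 1 and compound 2 are floors, each starting from a limit: the limit of > 50000 nM in this assay, at which 2 of the 4 values shown sit.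

Open, from the compounds shown here alone, is whether a thiophen-2-yl or an unsubstituted phenyl group on the same carbonyl carbon would track furan-2-yl or 4-methoxyphenyl. Going by these compounds, the true size of the two floored steps also stays unknown.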